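Methoxy added to the dimethoxyphenyl ketone of compound 1

The source may report more compounds than this note shows. Statements on the series, on what has been measured and on what is new or still open speak of the compounds shown alone.

Measured compounds:
- compound 1, `COc1ccc(C(=O)/C=C/c2cc(-c3cc(OC)c(OC)c(OC)c3)n[nH]2)cc1OC`, giving 97% in a functional assay on OVCAR-8 cells (Homo sapiens) for cytotoxicity, read by sulforhodamine B assay, with a stated time of 48 h, tested at 0.01 uM; a lower number here means a stronger effect, a higher number a weaker effect of the compound at the concentration tested
- compound 2, `COc1cc(-c2cc(/C=C/C(=O)c3ccc(F)c(F)c3)[nH]n2)cc(OC)c1OC`, giving 95% in this assay

Compound 1 holds the higher of the two numbers, yet the step of a number 2 percentage points lower from compound 1 to compound 2 (within the scatter) lies within the scatter, so the two cannot be told apart on these data. For the measured compounds named here, that step swaps the whole aryl group on the carbonyl carbon and is the only comparison available.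

Compound 3, `COc1cc(C(=O)/C=C/c2cc(-c3cc(OC)c(OC)c(OC)c3)n[nH]2)cc(OC)c1OC`, has not been measured in this assay. It differs from compound 1 by methoxy in place of hydrogen on an aromatic carbon, so the aryl on the carbonyl carbon gains a third methoxy and becomes the same trimethoxyphenyl that already sits on the shared core.

Going by the values given here, the one known change at this aryl, from compound 1 to compound 2, produced no movement beyond the scatter. A smaller change at the same place is therefore expected to leave the read-out where it is. The expected step of a number 2 percentage points lower from compound 1 to compound 3 (within the scatter) is none beyond the scatter. Compound 3 is estimated at 95%, within 82% to 104%.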

Compound 3, a percentage reported as activity, at one concentration (the size of the read-out at that concentration, not a potency): 100%
The estimate for compound 3 lay 5 percentage points below the measured number; low and high end bracket the measured number.
By their numbers in this assay, from the lowest: compounds 2, 1 and 3 (each within the scatter of the next).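

In this assay, methoxy in place of hydrogen on an aromatic carbon gives a number 3 percentage points higher from compound 1 to compound 3 (within the scatter), so this one added group does not separate the two compounds. The earlier comparison replaced the whole aryl group on the carbonyl carbon, whereas this step changes a single substituent on that aryl and likewise stays inside the scatter; it also shows that carrying the trimethoxyphenyl group at both ends of the molecule does not set compound 3 apart from compound 1 in this read-out. No available evidence bears on this result or links it to any property of the methoxy group.

Going by these compounds, it remains open whether a different group on this aromatic carbon, such as an amine, a carboxylic acid or a longer alkoxy chain, would move the number beyond the scatter. On these data alone, since the read-out comes from a single concentration and is not a potency, it also remains open whether compound 1 and compound 3 would differ at other concentrations.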